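Hydroxy for methylsulfanyl on the shared core

The compounds below may be only part of what the source reports. "The series", "measured", "known", "first", "only" and "open" are said of these compounds alone.

Compound 1 `CC(C)c1ncn2c(S)nncc12`: in a functional assay for inhibition, with Homo sapiens as the target (a lower number here means a stronger inhibitor, a higher number a weaker inhibitor), compound 1 gives > 48000 nM, a limit of the assay.
Compound 2 `CSc1nncc2c(C(C)C)ncn12`: in this assay compound 2 gives > 48000 nM, again a limit of the assay.

Compound 2 stands at the limit of > 48000 nM in this assay, at which 2 of the 2 values shown sit. Among the measured compounds shown here, the only measured step, a step that the two limits leave unreadable from compound 1 to compound 2, cannot be read: both of its ends are limits. Compound 3 `CC(C)c1ncn2c(O)nncc12` differs from compound 2 by hydroxy in place of methylsulfanyl on an aromatic carbon. No readable measured step bears on this change, so its size and direction have no measured anchor in this series. For the measured compounds named here, with every value so far at the limit, compound 3 is expected to sit at the same limit in this assay. The step that the limit leaves unreadable from compound 2 to compound 3 is therefore expected to stay within the scatter. The estimate for compound 3 in this assay is 60000 nM, with a range from 15000 nM to 250000 nM, and the most likely outcome is another limit rather than a number.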

Compound 3, half-maximal inhibitory concentration: > 48000 nM
Compound 3 gave a limit, no number (the forecaster's own chance of this, stated with the estimate: 80%); the middle value lies beyond the limit too.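

The steps among compound 1, compound 2 and compound 3 cannot be read, as each of the three compounds gives only a limit in this assay: the limit of > 48000 nM in this assay, at which 3 of the 3 values shown sit.

The compounds shown leave open whether any substituent on the shared core gives a readable value in this assay.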